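Compound 3 to compound 4: working notes on clearance

A few compounds are considered here, and "the series" means these few. Any claim that something is new, unique, unknown or untested is made for them only; others in the source may bear on it.

Measured in an ADME assay (liver) for metabolic stability, with Liver microsome (Homo sapiens) as the target, read by LC-MS, using microsomes and NADPH, with a stated time of 5 min, at 37 degrees C; on this read-out higher numbers stand for fast clearance and lower numbers for slow clearance:
- compound 1 `CCn1c([C@@H](C)NS(=O)(=O)c2ccc(Cl)cc2)nc2ccccc21`: > 100 mL.min-1.g-1 (a limit of the assay)
- compound 2 `CCn1c([C@@H](C)NS(=O)(=O)c2ccc(Cl)cc2)nc2ccc(OC)cc21`: > 100 mL.min-1.g-1 (a limit of the assay)
- compound 3 `CCn1c([C@@H](C)NS(=O)(=O)c2ccc(Cl)cc2)nc2ccc(CO)cc21`: 84 mL.min-1.g-1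

For the measured compounds named here, compound 3 gives 84 mL.min-1.g-1, the only actual number in the set. The other two readings rest on (the limit of > 100 mL.min-1.g-1 in this assay, at which 2 of the 3 values shown sit), and they cannot be ranked against each other.

Next in line is compound 4 `CCn1c([C@@H](C)NS(=O)(=O)c2ccc(Cl)cc2)nc2ccc(CN(C)C)cc21`, not yet measured. The change is dimethylamino in place of hydroxy on a saturated chain carbon bound to an aromatic carbon, which also reads as hydroxymethyl to (dimethylamino)methyl.

Going by the values given here, three measured steps bear on it, and none gives a firm size. The two that end at compound 3 are an at least 1.1-fold lower number from compound 1 to compound 3 (0.07 log units; that floor lies within the scatter) and an at least 1.1-fold lower number from compound 2 to compound 3 (0.07 log units; that floor lies within the scatter). Both are floors only. The third, a step that the two limits leave unreadable from compound 1 to compound 2, adds no size either. Among the compounds with values here, no measured step replaces the hydroxy itself. With no size to carry over, no step beyond the scatter is expected in this assay, in either direction. The estimated move is a 1.0-fold higher number from compound 3 to compound 4 (0.01 log units; within the scatter). For compound 4 the expected value is 85 mL.min-1.g-1, with an estimated range of 42 mL.min-1.g-1 to 170 mL.min-1.g-1.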

Compound 4, intrinsic clearance in microsomes: 30 mL.min-1.g-1
Estimate against measurement, compound 4: 2.8-fold (0.45 log units) above, outside the stated range (below it).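

In this assay, for the compounds shown here, the group on the saturated chain carbon bound to an aromatic carbon turns out to matter, with a 2.8-fold lower number from compound 3 to compound 4 (0.45 log units; beyond the scatter), the first step of readable size beyond the scatter in this set. Against the two compounds that lack this chain, the (dimethylamino)methyl group also clears the scatter, with an at least 3.3-fold lower number from compound 1 to compound 4 (0.52 log units; beyond the scatter) and an at least 3.3-fold lower number from compound 2 to compound 4 (0.52 log units; beyond the scatter), whereas the floors for hydroxymethyl in the same comparisons stayed within it. These last two steps give floors and not full sizes, because compound 1 and compound 2 each sit at a limit of the assay: the limit of > 100 mL.min-1.g-1 in this assay, at which 2 of the 4 values shown sit.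

The compounds shown leave open whether the lower number follows the nitrogen of the dimethylamino group or only the larger group, and a methoxy or an ethyl on the same saturated chain carbon would separate these two readings. Also open, from the compounds shown here alone, is how a primary amine, a cyclic amine such as morpholine, a carboxylic acid or a longer chain carrying the dimethylamino group would read in this assay.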